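This account rests on a few compounds, and the source may have more. Where it says the series, first, only, none or still open, it means among the compounds named here.

Measured: compound 1 `COc1cc2nc(/C=C\c3ccncc3)c(=O)n(CC(=O)Nc3ccccc3)c2cc1OC`, compound 2 `Cc1ccc(NC(=O)COc2nc3ccccc3nc2C)cc1`, compound 3 `Cc1nc2ccccc2nc1OCC(=O)Nc1ccc(Cl)cc1`. In a functional assay on MCF7 cells (Homo sapiens) for inhibition, read by MTT assay, with a stated time of 24 h (on this read-out lower numbers stand for stronger inhibition and higher numbers for weaker inhibition), compound 1 gives only the limit > 100000 nM. Compound 2 also reaches only the limit > 100000 nM. Compound 3 likewise stops at the limit > 100000 nM. Compound 2 therefore stands at the limit, where all three values sit (the limit of > 100000 nM in this assay, at which 3 of the 3 values shown sit). Within the data shown here, the one measured step, a step that the two limits leave unreadable from compound 2 to compound 3, cannot be read for size. Compound 4 `Cc1ccc(NC(=O)COc2nc3ccccc3nc2/C=C\c2ccncc2)cc1` differs from compound 2 by 2-(pyridin-4-yl)ethenyl in place of methyl on an aromatic carbon. The entering 2-(pyridin-4-yl)ethenyl group appears among the measured compounds only in compound 1, which also sits at the limit. Among the measured compounds shown here, no measured step thus gives a readable size for the step from compound 2 to compound 4 in this assay. Compound 4 is expected at 100000 nM, between 20000 nM and 400000 nM, an estimated a number no higher from compound 2 to compound 4 (the limit leaves the size open).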

Compound 4, half-maximal inhibitory concentration: 60200 nM
Beside the measured number, compound 4's estimate is 1.7-fold (0.22 log units) above it; low and high end bracket the measured number.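

Placing 2-(pyridin-4-yl)ethenyl in place of methyl on this aromatic carbon gives an at least 1.6-fold lower number from compound 2 to compound 4 (0.22 log units; that floor lies within the scatter) in this assay. Among these compounds, compound 4 thus gives the first number at this position that is not a limit, while the other values remain limits: the limit of > 100000 nM in this assay, at which 3 of the 4 values shown sit. The group does not bring this about in every compound, since compound 1 also carries it and gives only the limit > 100000 nM.

The step between the limits of the methyl and chloro compounds still cannot be read. Also open, as far as these compounds go, is what a smaller group, such as an amine or a carboxylic acid, would give on this aromatic carbon.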